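A small swap on the benzyl group

The compounds below may be only part of what the source reports. "The series", "measured", "known", "first", "only" and "open" are said of these compounds alone.

compound 1 `COc1ccc(CN2C(=O)/C(=C\c3cc(OC)c(OC)c(OC)c3)c3ccccc32)cc1` gives 2500 nM
compound 2 `COc1cc(/C=C2/C(=O)N(C)c3ccc(O)cc32)cc(OC)c1OC` gives 4300 nM
compound 3 `COc1ccc2c(c1)/C(=C\c1cc(OC)c(OC)c(OC)c1)C(=O)N2C` gives 2400 nM

These three numbers come from a functional assay on cells (Cancer cell lines, Homo sapiens) for cytotoxicity, with a stated time of 48 h (on this read-out higher numbers stand for weaker inhibition of growth and lower numbers for stronger inhibition of growth), and lie close together. Compound 1 at 2500 nM sits within the usual scatter of both other compounds, so the numbers give no clear ranking among them.

Compound 4 `COc1cc(/C=C2\C(=O)N(Cc3ccc(Cl)cc3)c3ccccc32)cc(OC)c1OC` has not yet been measured. Its change from compound 1 reads chloro in place of methoxy on an aromatic carbon and in words it is chloro in place of methoxy on an aromatic carbon, para to a large group, which turns 4-methoxybenzyl into 4-chlorobenzyl.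

Within the data shown here, no measured pair makes this exact exchange. Among the measured compounds shown here, the only measured step that alters a single place is a 1.8-fold lower number from compound 2 to compound 3 (0.25 log units; within the scatter) and it concerns a different substituent at another place in the molecule, so it is only a loose guide. It does show that one small substituent change left the number within the scatter here. On that thin evidence, no shift beyond the scatter is expected in this assay for the new compound, and no direction can be favoured. The estimated step is no change at the digits printed from compound 1 to compound 4 (within the scatter) and it is expected to stay within the scatter. Compound 4 is expected at 2500 nM with an estimated range from 800 nM to 7000 nM in this test.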

Compound 4, concentration for 50% growth inhibition: 3400 nM
Compound 4: middle estimate off by 1.4-fold (0.13 log units), on the low side; the measured number falls inside the stated range.
By their numbers in this assay, from the lowest: compounds 3, 1, 4 and 2 (each within the scatter of the next).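

Among these compounds, replacing the methoxy of the 4-methoxybenzyl group with chloro gives the first direct reading at this position: in this assay, the exchange produces a 1.4-fold higher number from compound 1 to compound 4 (0.13 log units; within the scatter). Among the compounds shown here, in this one pair, a group of two heavy atoms with one hydrogen-bond acceptor gives way to a single chlorine atom with no acceptor, and the number stays within the scatter, whereas the only earlier single-place step concerned a different place in the molecule. No measured property of these compounds bears on this result, so the data offer no explanation for it.

From the compounds shown here alone, a single pair of groups says little about how much variety this position accepts, so it remains open whether an amine, a carboxylic acid or a longer chain such as butoxy in the place of the methoxy or chloro would also leave the number within the scatter. Going by these compounds, it also remains open whether the benzyl group as a whole matters, and whether the same exchange of methoxy for chloro would give a similar result at another place on the shared core.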